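Anilino for benzyloxy on the shared core: cytotoxicity notes

The compounds below may be only part of what the source reports. "The series", "measured", "known", "first", "only" and "open" are said of these compounds alone.

The series is followed in a functional assay on SEM cells (Homo sapiens) for cytotoxicity, with a stated time of 72 h; on this read-out higher numbers stand for an effect only at larger amounts of compound and lower numbers for an effect already at smaller amounts. Compound 1 `C=C[C@@](C)(/C=C/c1ccc(OCc2ccccc2)cc1)CCC=C(C)C` reaches only the limit > 36600 nM in this assay, so no number is known for it. Compound 2 `C=C[C@@](C)(/C=C/c1ccc(O)c(/C=C/C=C/c2ccccc2)c1)CCC=C(C)C` likewise returns only the limit > 15000 nM. Both values shown are limits, so compound 1 stands with compound 2 at the edge of what this assay resolves, as shown by the limit of > 36600 nM in this assay, at which 1 of the 2 values shown sits, and (the limit of > 15000 nM in this assay, at which 1 of the 2 values shown sits). Within the data shown here, no step between measured compounds can be drawn from two limits.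

Compound 3 `C=C[C@@](C)(/C=C/c1ccc(Nc2ccc(Cl)cc2)cc1)CCC=C(C)C` differs from compound 1 by (4-chlorophenyl)amino in place of benzyloxy on an aromatic carbon. With both measured compounds at limits, the step in this assay is expected to be none beyond the scatter, and an effect at smaller amounts would be a departure from compound 1 and compound 2. The estimate for compound 3 is 30000 nM, expected to fall between 8000 nM and 100000 nM. This estimate means an expected step of an at least 1.2-fold lower number from compound 1 to compound 3 (0.08 log units; that floor lies within the scatter), most likely reported again as a limit.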

Compound 3, half-maximal effective concentration: > 36600 nM
Compound 3 was reported as a limit; the forecaster's own chance of this, stated with the estimate: 70%; middle value at least 1.2-fold (0.08 log units) from the limit.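

In this assay compound 3 gives > 36600 nM, a limit and not a number. Among these compounds, compound 1 also stands at a limit, so no step between compound 1 and compound 3 can be read. The compounds shown leave open whether (4-chlorophenyl)amino in place of benzyloxy alters the read-out at all.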